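Nitro for cyano on two cores

The source may report more compounds than this note shows. Statements on the series, on what has been measured and on what is new or still open speak of the compounds shown alone.

Compound 1 `CC(O)(COc1cc(C(F)(F)F)cc(C(F)(F)F)c1)C(=O)Nc1ccc(C#N)cc1C(F)(F)F` is the open-chain anilide of the set; in a functional assay on VCaP cells (Homo sapiens) for antiproliferative activity, read by fluorescence and propidium iodide staining, with a stated time of 96 h (a higher number here means a weaker inhibitor, a lower number a stronger inhibitor), compound 1 gives 4770 nM. Compound 2 `CC(O)(COc1cc(C(F)(F)F)cc(C(F)(F)F)c1)C(=O)Nc1ccc([N+](=O)[O-])cc1C(F)(F)F` carries the change nitro in place of cyano on an aromatic carbon and in this assay compound 2 gives 23700 nM. The step of a 5.0-fold higher number from compound 1 to compound 2 (0.70 log units; beyond the scatter) is a clear loss for the nitro compound. Compound 3 `CC1(C)C(=O)N(c2ccc(C#N)cc2C(F)(F)F)C(=S)N1c1cc(C(F)(F)F)cc(C(F)(F)F)c1` is built on a cyclic core; the difference between the core of compound 3 and the core of compound 1 is not broken down here. In this assay compound 3 gives "nd(insoluble)" (no result reported), so no number is available for it. Compound 4 `CC1(C)C(=O)N(c2ccc([N+](=O)[O-])cc2C(F)(F)F)C(=S)N1c1cc(C(F)(F)F)cc(C(F)(F)F)c1` stands to compound 3 as compound 2 stands to compound 1: the change nitro in place of cyano on an aromatic carbon is the same change, at a place described in identical terms. With no number for compound 3, the expectation for compound 4 rests only on the step of a 5.0-fold higher number from compound 1 to compound 2 (0.70 log units; beyond the scatter), which points toward a weaker inhibitor after the nitro swap, and on the absent result for compound 3, which may recur for compound 4. Compound 4 is expected to give about 3000 nM, with a wide range from 500 nM to 20000 nM.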

Compound 4, half-maximal inhibitory concentration: 18600 nM
Compound 4: middle estimate off by 6.2-fold (0.79 log units), on the low side; the range from low to high includes it.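

No step can be read from compound 3 to compound 4: in this assay compound 3 gives "nd(insoluble)" (no result reported), and compound 4 gives 18600 nM. On these data alone, whether nitro in place of cyano shifts the number on the core of compound 3 as it does on the core of compound 1 stays open. No measured evidence bears on this result.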